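Inverting One Ring Stereocentre on the Way to Compound 4

This account rests on a few compounds, and the source may have more. Where it says the series, first, only, none or still open, it means among the compounds named here.

The series rests on a shared core carrying a three-carbon chain to a phenyl group. Compound 1 `CC[C@]1(CCCc2ccccc2)C(=O)N(c2ccc(OC)cc2)[C@@H]1c1ccccc1` gives 33% in an assay for inhibition of sterol O-acyltransferase 1 (Rattus norvegicus), using microsomes, tested at 10 uM; a lower number here means less inhibition, a higher number more inhibition at the concentration tested (going by the name of the read-out). Compound 2 `CC[C@]1(CCCc2ccccc2)C(=O)N(c2c(OC)cc(OC)cc2OC)[C@@H]1c1ccccc1` gives 42%. Compound 3 `COc1cc(OC)c(N2C(=O)[C@@H](CCCc3ccccc3)[C@H]2c2ccccc2)c(OC)c1` gives 61%. Compound 4 `CC[C@@]1(CCCc2ccccc2)C(=O)N(c2c(OC)cc(OC)cc2OC)[C@@H]1c1ccccc1` is not yet measured.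

Compound 2 stands second of the three numbers: its gap to compound 1 lies within the scatter, while compound 3 sits beyond it, the step of a number 19 percentage points higher from compound 2 to compound 3 (beyond the scatter) coming with hydrogen in place of ethyl on a saturated ring carbon.

Compound 4 differs from compound 2 as follows: the two compounds have the same atoms and bonds and differ only in configuration as drawn: 1 of 2 stereo elements differ; a stereocentre at a saturated ring carbon is drawn R in compound 2 and S in compound 4. Within the data shown here, no measured step changes only a configuration; the one step that touches this carbon removes the ethyl altogether and is modest. Among the measured compounds shown here, with no step of the same kind to lean on, the estimated change a number 2 percentage points lower from compound 2 to compound 4 (within the scatter) is expected to stay small, with wide uncertainty. Compound 4 is therefore expected to give about 40% in this assay, within the range 15% to 65%.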

Compound 4, a percentage reported as inhibition, at one concentration (the size of the read-out at that concentration, not a potency): 82%
Compound 4: middle estimate off by 42 percentage points, on the low side, outside the stated range (above it).
By their numbers in this assay, from the lowest: compounds 1 and 2 (each within the scatter of the next); then compound 3; then compound 4.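

With a number 40 percentage points higher from compound 2 to compound 4 (beyond the scatter), the configuration at this saturated ring carbon proves to matter a great deal in this assay, even though no atom or bond changes. The earlier compounds shown here had tested this carbon only by swapping a group, and that step, a number 19 percentage points higher from compound 2 to compound 3 (beyond the scatter), was modest and could not show that the spatial arrangement of the same ethyl and chain could outweigh it. The gain can be assigned to this one stereocentre alone, because nothing else separates the pair: the fact that compounds 2 and 4 differ only in the configuration as drawn

Still open, going by these compounds, is whether inverting this carbon gives a step of similar size with the aryl group of compound 1, and whether the second stereocentre matters as much. Also open, on these data alone, is how a methyl group or a longer chain in place of ethyl would behave in the configuration of compound 4.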